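Benzyl ether in place of the fluorophenyl ketone chain

This account rests on a few compounds, and the source may have more. Where it says the series, first, only, none or still open, it means among the compounds named here.

Among three compounds sharing one core, compound 1 `Cc1nn(-c2ncnc3nc[nH]c23)c2c1C(OCC(=O)c1ccc(F)cc1)CC(=O)N2` stands at the low end of the numbers in a functional assay on HEK293 cells for agonist activity at G-protein coupled receptor 39 (Homo sapiens), read by scintillation proximity assay and inositol phosphate accumulation, with a stated time of 75 min, in the presence of a further agent that is not named here (on this read-out lower numbers stand for an effect already at smaller amounts and higher numbers for an effect only at larger amounts of compound), with 3 nM. Compound 3 `Cc1nn(-c2ncnc3nc[nH]c23)c2c1C(OCc1ccc(C#N)cc1)CC(=O)N2` gives 4 nM in this assay, and compound 2 `Cc1nn(-c2ncnc3nc[nH]c23)c2c1C(C(=O)Nc1ccccc1)CC(=O)N2` gives 10 nM. The step of a 1.3-fold higher number from compound 1 to compound 3 (0.12 log units; within the scatter) lies within the scatter, so compounds 1 and 3 cannot be ordered, while a 2.5-fold lower number from compound 2 to compound 3 (0.40 log units; beyond the scatter) is a modest step beyond it. Compound 4 `Cc1nn(-c2ncnc3nc[nH]c23)c2c1C(OCCc1ccccc1)CC(=O)N2` has not yet been measured in this assay. It differs from compound 1 at a single place: benzyl in place of (4-fluorophenyl)carbonyl on a saturated chain carbon bound to an oxygen on a saturated carbon. Within the data shown here, the one measured step that bears on this change sits at the same place, a 1.3-fold higher number from compound 1 to compound 3 (0.12 log units; within the scatter), where the (4-fluorophenyl)carbonyl gave way to 4-cyanophenyl without moving the number beyond the scatter. Among the measured compounds shown here, no measured pair isolates the removal of the carbonyl or the fluorine. A small step, if any, is therefore expected for compound 4, a 2.0-fold higher number from compound 1 to compound 4 (0.30 log units; within the scatter). The estimate for compound 4 in this assay is 6 nM, within a range from 2 nM to 20 nM.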

Compound 4, half-maximal effective concentration: 3 nM
Compound 4: middle estimate off by 2.0-fold (0.30 log units), on the high side; the range from low to high includes it.
By their numbers in this assay, from the lowest: compounds 1, 4 and 3 (each within the scatter of the next); then compound 2.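

At this place, on a saturated chain carbon bound to an oxygen on a saturated carbon, the carbonyl and the fluorine of compound 1 can both be absent in this assay with no visible cost (no change at the digits printed from compound 1 to compound 4 (within the scatter)). The unsubstituted phenyl ring of the phenethyl chain also stands level with the 4-cyanophenyl group (a 1.3-fold lower number from compound 3 to compound 4 (0.12 log units; within the scatter)), so neither ring substituent shown is needed to hold the number here. The phenethyloxy group also keeps an advantage over phenylcarbamoyl on the saturated ring carbon (a 3.3-fold lower number from compound 2 to compound 4 (0.52 log units; beyond the scatter)), a modest step beyond the scatter.

As far as these compounds go, it remains open whether an amine or a carboxylic acid on that phenyl ring, or a chain longer than phenethyl, would still be tolerated. Nothing at hand explains why these changes leave the number in place.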